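The compounds below may be only part of what the source reports. "The series", "measured", "known", "first", "only" and "open" are said of these compounds alone.

Measured so far:
Compound 1, `Cc1ccc(F)cc1S(=O)(=O)N1CCN(c2ccc(C(=O)NCc3ccc(F)cc3)nn2)CC1`, gives 0.78 in an ADME assay on microsomes from liver (Homo sapiens), read by LC-MS, using NADPH, tested at 10 uM; a higher number here means that the liver removes a larger share of the compound in one pass, a lower number that the liver removes a smaller share.
Compound 2, `O=C(NCc1ccccc1)c1ccc(N2CCN(S(=O)(=O)c3cccc(Cl)c3Cl)CC2)nn1`, gives 0.73 in this assay.

Among the measured compounds shown here, only two numbers are known, and compound 2 holds one of them; the other, from compound 1, sits apart from it by an amount within the usual scatter, so the two compounds cannot be separated by their values in this assay.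

Compound 3, `O=C(NCc1ccccc1)c1ccc(N2CCN(S(=O)(=O)c3ccccc3Cl)CC2)nn1`, has not yet been measured. It differs from compound 2 in one place: hydrogen in place of chloro on an aromatic carbon. The change is small and touches no ring and no donor or acceptor. For the measured compounds named here, no step between measured compounds shows what such a change does here, so there is no measured guide. Compound 3 is expected to show a step of a number 0.030 lower from compound 2 to compound 3 (within the scatter), which is none beyond the scatter. Compound 3 is therefore estimated at 0.7 in this assay, with a range from 0.55 to 0.85.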

Compound 3, hepatic extraction ratio: 0.89
Estimate against measurement, compound 3: 0.19 below, outside the stated range (above it).
By their numbers in this assay, from the lowest: compounds 2 and 1 (each within the scatter of the next); then compound 3.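

In this assay, the change from (2,3-dichlorophenyl)sulfonyl to (2-chlorophenyl)sulfonyl gives a step of a number 0.16 higher from compound 2 to compound 3 (beyond the scatter). Among the compounds shown here, compound 1 and compound 2 differ in more than one place and gave no reading of any single change, so this pair is the first to show that this position matters: with hydrogen in place of chloro on this aromatic carbon, the liver removes a larger share of the compound. Nothing measured here explains why the share rises with this change.

The compounds shown leave open whether a methoxy group or a nitrile on the same aromatic carbon would keep the lower number of compound 2 or follow compound 3. They also leave open what hydrogen in place of the remaining chloro would do.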